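Bromo to nitrooxy on a furan and a chlorophenyl chalcone

The source may report more compounds than this note shows. Statements on the series, on what has been measured and on what is new or still open speak of the compounds shown alone.

Measured so far:
compound 1, `O=C(CBr)Nc1ccc(C(=O)/C=C/c2ccco2)cc1`, 41%
compound 2, `O=C(CO[N+](=O)[O-])Nc1ccc(C(=O)/C=C/c2ccco2)cc1`, 48%
compound 3, `CC(Br)C(=O)Nc1ccc(C(=O)/C=C/c2ccc(Cl)cc2)cc1`, 59%

In a functional assay on the whole organism (strain albino) for inhibition, with Rattus norvegicus as the target, read by paw edema, with stated times of 30 min and 3 h, at a dose of 100 mg/kg by the oral route (on this read-out higher numbers stand for more inhibition at the one dose given (going by the name of the read-out) and lower numbers for less inhibition), compound 1 gives 41% and compound 2 gives 48%. The change between them is nitrooxy in place of bromo on a saturated chain carbon bound to a carbonyl carbon, and the step it made is a number 7 percentage points higher from compound 1 to compound 2 (within the scatter). Compound 3 gives 59% in this assay; how its core differs from that of compound 1 is not broken down here. Compound 4, `CC(O[N+](=O)[O-])C(=O)Nc1ccc(C(=O)/C=C/c2ccc(Cl)cc2)cc1`, is not yet measured. It differs from compound 3 by nitrooxy in place of bromo on a saturated chain carbon bound to a carbonyl carbon and a saturated chain carbon. This is the same kind of change as from compound 1 to compound 2, though the place now is a saturated chain carbon bound to a carbonyl carbon and a saturated chain carbon rather than to a carbonyl carbon alone. Because the earlier step was a number 7 percentage points higher from compound 1 to compound 2 (within the scatter), a step of about a number 6 percentage points higher from compound 3 to compound 4 (within the scatter) is expected on the core of compound 3. Going by the values given here, compound 4 is therefore estimated at 65%, within 53% to 77%, resting on only one earlier instance of the change.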

Compound 4, a percentage reported as inhibition, in the whole organism at one dose (the size of the read-out at that dose, not a potency): 62%
Beside the measured number, compound 4's estimate is 3 percentage points above it, within the range that was stated.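

In this assay, nitrooxy in place of bromo on the second core gave a number 3 percentage points higher from compound 3 to compound 4 (within the scatter). Set beside the earlier step, it does not differ from it: the same change on two cores in this assay, a number 7 percentage points higher (within the scatter) from compound 1 to compound 2 and a number 3 percentage points higher (within the scatter) from compound 3 to compound 4, 4 percentage points apart, within the scatter of two such steps. The change thus carried from one core to the other with a similar small step, but neither step can be told from scatter, so this does not show that nitrooxy gives more inhibition than bromo on either core, and two pairs cannot speak for other cores in the series.

The compounds shown leave open whether another group at this place, such as an amine or a carboxylic acid, would give a step beyond the scatter. They also leave open what a longer chain carrying the nitrooxy group would do.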